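This account rests on a few compounds, and the source may have more. Where it says the series, first, only, none or still open, it means among the compounds named here.

Measured so far:
compound 1 `COc1ccc(-c2cc(/C=C/C(=O)c3ccc(N)cc3)[nH]n2)cc1` — 2000 nM
compound 2 `COc1cc(-c2cc(/C=C/C(=O)c3ccc(N)cc3)[nH]n2)cc(OC)c1OC` — 1710 nM

In a functional assay on NCI-H226 cells (Homo sapiens) for inhibition, read by sulforhodamine B assay, with a stated time of 48 h (a higher number here means a weaker inhibitor of growth, a lower number a stronger inhibitor of growth), compound 1 gives 2000 nM. Compound 2 gives 1710 nM, the lower of the two numbers, but the gap to compound 1 lies within the scatter, so the two compounds are not ordered by this assay. Compound 3 `COc1cc(-c2cc(/C=C/C(=O)c3ccc(F)c(F)c3)[nH]n2)cc(OC)c1OC` has not yet been measured. It differs from compound 2 by 3,4-difluorophenyl in place of 4-aminophenyl on a carbonyl carbon. Within the data shown here, no step between measured compounds shows what this exchange does in this assay, and the two measured values do not speak to it. The expected step in this assay is a 1.2-fold higher number from compound 2 to compound 3 (0.07 log units; within the scatter), with no direction favoured beyond the scatter. Compound 3 is estimated at 2000 nM, with a range from 600 nM to 7000 nM.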

Compound 3, concentration for 50% growth inhibition: 3720 nM
Compound 3: the middle estimate sits 1.9-fold (0.27 log units) below what was measured; the measured number falls inside the stated range.
By their numbers in this assay, from the lowest: compounds 2, 1 and 3 (each within the scatter of the next, the first and the last beyond it).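

Among these compounds, on the carbonyl carbon, 3,4-difluorophenyl in place of 4-aminophenyl gives a 2.2-fold higher number from compound 2 to compound 3 (0.34 log units; beyond the scatter) in this assay, the first step that lies beyond the scatter, though it is modest in size. This position is therefore not indifferent to the group it carries, and the 4-aminophenyl of compound 2 gives the lower number of this pair. No measurement on hand accounts for the step.

On these data alone, it remains open whether the step follows from losing the amine, from adding the two fluorines, or from both; an unsubstituted phenyl or a 4-hydroxyphenyl on the same carbonyl carbon would help separate these. Also open, as far as these compounds go, is whether the same exchange gives a similar step on the core of compound 1.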